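Fluoro added to the central phenyl of compound 2

The compounds below may be only part of what the source reports. "The series", "measured", "known", "first", "only" and "open" are said of these compounds alone.

Of the compounds shown here, three of one series have been measured in a functional assay on MCF7 cells (Homo sapiens) for cytotoxicity, read by MTT assay, with a stated time of 72 h; on this read-out higher numbers stand for weaker inhibition and lower numbers for stronger inhibition. Compound 1 `Cc1cc(=O)n(-c2ccccc2OC(F)(F)F)nc1C(=O)Nc1ccc(Oc2ncnc3c2ccn3C)cc1` gives 27000 nM; compound 2 `Cc1cc(=O)n(-c2cccc(F)c2)nc1C(=O)Nc1ccc(Oc2ncnc3c2ccn3C)cc1` gives 30800 nM; compound 3 `Cc1ccc(-n2nc(C(=O)Nc3ccc(Oc4ncnc5c4ccn5C)cc3)c(C)cc2=O)cc1` gives 10800 nM. Compound 2 holds the highest number of the three: its gap to compound 1 lies within the scatter, while a 2.9-fold lower number from compound 2 to compound 3 (0.46 log units; beyond the scatter) and a 2.5-fold lower number from compound 1 to compound 3 (0.40 log units; beyond the scatter) are modest and beyond it. Compound 4 `Cc1cc(=O)n(-c2cccc(F)c2)nc1C(=O)Nc1ccc(Oc2ncnc3c2ccn3C)c(F)c1` differs from compound 2 by fluoro in place of hydrogen on an aromatic carbon. Going by the values given here, every measured step alters the aryl group on the aromatic nitrogen; none touches the ring that carries the amide nitrogen, so no measured step bears on this change. Without such a guide, the expected step of a 1.0-fold lower number from compound 2 to compound 4 (0.01 log units; within the scatter) is none beyond the scatter. Compound 4 is therefore estimated at 30000 nM, with a range of 12000 nM to 75000 nM.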

Compound 4, half-maximal inhibitory concentration: > 60000 nM
Compound 4: a limit, no number; the forecaster's own chance of this, stated with the estimate: 10%; middle value at least 2.0-fold (0.30 log units) away from the limit.
By their numbers in this assay, from the lowest: compound 3; then compounds 1 and 2 (each within the scatter of the next). At a limit, above all of these: compound 4.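

Compound 4 gives > 60000 nM in this assay, which is a limit and not a number. Going by these compounds alone, this is the first reading from the ring that carries the amide nitrogen, and fluoro in place of hydrogen there gives an at least 1.9-fold higher number from compound 2 to compound 4 (0.28 log units; that floor lies within the scatter), with no sign of stronger inhibition from this change. Only a floor can be read from this step, not its size: the limit of > 60000 nM in this assay, at which 1 of the 4 values shown sits.

From the compounds shown here alone, whether a methyl, a methoxy or an amine on this carbon would lower the number stays open. So does whether fluoro here acts the same way alongside the 4-methylphenyl of compound 3.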